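Sulfonyl aryl variation in the shared core series

This account rests on a few compounds, and the source may have more. Where it says the series, first, only, none or still open, it means among the compounds named here.

Three compounds share the core of compound 1 `Cc1ccc(S(=O)(=O)N2CCN(C[C@H](C)Nc3ncnc4c(C)csc34)CC2)cc1` and differ only in the group on the sulfonyl sulfur. In a functional assay on RH7777 cells for antagonist activity at lysophosphatidic acid receptor 2 (Homo sapiens), read by calcium flux (a lower number here means a stronger inhibitor, a higher number a weaker inhibitor), compound 1 gives 170 nM. Compound 2 `Cc1csc2c(N[C@@H](C)CN3CCN(S(=O)(=O)c4ccc(Cl)c(Cl)c4)CC3)ncnc12` gives 17 nM in this assay, and compound 3 `Cc1csc2c(N[C@@H](C)CN3CCN(S(=O)(=O)c4cccc(Cl)c4)CC3)ncnc12` gives 35 nM. Compound 3 thus stands second highest of the three: the step of a 2.1-fold higher number from compound 2 to compound 3 (0.31 log units; beyond the scatter) is beyond the scatter, as is a 4.9-fold lower number from compound 1 to compound 3 (0.69 log units; beyond the scatter).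

Compound 4 `Cc1csc2c(N[C@@H](C)CN3CCN(S(=O)(=O)Cc4ccccc4)CC3)ncnc12` is not yet measured. The change is benzyl in place of 3-chlorophenyl on a sulfonyl sulfur. Every measured step touches the same sulfonyl substituent: a 10-fold lower number from compound 1 to compound 2 (1.00 log units; beyond the scatter), a 4.9-fold lower number from compound 1 to compound 3 (0.69 log units; beyond the scatter) and a 2.1-fold higher number from compound 2 to compound 3 (0.31 log units; beyond the scatter). None of them swaps an aryl for a benzyl, so the measured steps bear only indirectly. Loss of chloro already raised the number in a 2.1-fold higher number from compound 2 to compound 3 (0.31 log units; beyond the scatter), and the chlorine-free 4-methylphenyl of compound 1 sits highest; the benzyl of compound 4 carries no chlorine either. A higher number in this assay is therefore expected, a 7.1-fold higher number from compound 3 to compound 4 (0.85 log units; beyond the scatter). Compound 4 is estimated at 250 nM, within 80 nM to 800 nM.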

Compound 4, half-maximal inhibitory concentration: 1860 nM
Estimate against measurement, compound 4: 7.4-fold (0.87 log units) below; the whole stated range lies below it.
By their numbers in this assay, from the lowest: compound 2; then compound 3; then compound 1; then compound 4.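

Benzyl on the sulfonyl sulfur gives a 53-fold higher number from compound 3 to compound 4 (1.73 log units; beyond the scatter) and a 110-fold higher number from compound 2 to compound 4 (2.04 log units; beyond the scatter), so this position in this assay discriminates far more sharply than the aryl groups alone indicated. Absence of chlorine does not account for the result, since compound 1 also carries no chlorine and the change from its 4-methylphenyl still gives an 11-fold higher number from compound 1 to compound 4 (1.04 log units; beyond the scatter); among these four compounds, the benzyl of compound 4 therefore stands apart from all three groups with the ring directly on the sulfonyl sulfur. No measurement shown here bears on what lies behind this difference.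

From the compounds shown here alone, it remains open whether a 3-chlorobenzyl or 3,4-dichlorobenzyl on the sulfonyl sulfur would recover the lower numbers of the chlorinated aryl compounds. Going by these compounds, how a longer phenethyl chain, or a methyl with no ring at all, would read at this position is also open.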